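A few compounds are considered here, and "the series" means these few. Any claim that something is new, unique, unknown or untested is made for them only; others in the source may bear on it.

All three measured compounds were tested in a functional assay on ACHN cells (Homo sapiens) for inhibition, read by sulforhodamine B assay, with a stated time of 48 h, tested at 100 uM; on this read-out higher numbers stand for a weaker effect at the one concentration tested and lower numbers for a stronger effect.

compound 1 `O=C(Nc1cccc(-n2cc(-c3ccncc3)c(-c3cc(O)cc(Cl)c3)n2)c1)Nc1ccc(Cl)c(C(F)(F)F)c1`: -25%
compound 2 `O=C(Nc1cccc(-n2cc(-c3ccncc3)c(-c3cc(O)cc(Cl)c3)n2)c1)Nc1ccc(Cl)c(Cl)c1`: -33%
compound 3 `COc1cc(Cl)cc(-c2nn(-c3cccc(NC(=O)Nc4cc(C(F)(F)F)cc(C(F)(F)F)c4)c3)cc2-c2ccncc2)c1`: -38%

Compound 3 holds the lowest of the three numbers. Its gap to compound 2 lies within the scatter, so the two are not separable; its gap to compound 1 lies beyond the scatter, so compound 3 reads as the stronger of that pair at the one concentration tested.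

Compound 4 `COc1cc(Cl)cc(-c2nn(-c3cccc(NC(=O)Nc4cccc(C(F)(F)F)c4)c3)cc2-c2ccncc2)c1` differs from compound 3 in one place: hydrogen in place of trifluoromethyl on an aromatic carbon. Going by the values given here, the only measured step touching the same terminal ring of the urea is a number 8 percentage points lower from compound 1 to compound 2 (within the scatter), where one small group stood in for another and the read-out stayed within the scatter. Among the compounds with values here, no measured pair shows a trifluoromethyl giving way to hydrogen, so that step is a loose guide only, and the series gives no sign that the groups on this ring move the number much.

For compound 4 the step of a number 6 percentage points higher from compound 3 to compound 4 (within the scatter) is therefore expected to stay within the scatter, with no direction favoured. The estimate for compound 4 in this assay is -32%, within the range -52% to -12%.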

Compound 4, a percentage reported as activity, at one concentration (the size of the read-out at that concentration, not a potency): -9%
For compound 4 the middle estimate is 23 percentage points below the measured one; the whole stated range lies below it.
By their numbers in this assay, from the lowest: compounds 3, 2 and 1 (each within the scatter of the next, the first and the last beyond it); then compound 4.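

In this assay, this position on the six-membered aromatic ring of carbon only is not indifferent to the change: with hydrogen in place of trifluoromethyl, the series shows a number 29 percentage points higher from compound 3 to compound 4 (beyond the scatter), a weaker effect at the one concentration tested even though compound 4 keeps a trifluoromethyl group on the same ring. Going by these compounds alone, the only earlier step on a ring of this kind, a number 8 percentage points lower from compound 1 to compound 2 (within the scatter), replaced trifluoromethyl with chloro, so a group remained at the changed place; the new step is the first to leave only hydrogen there, though the two steps sit on different compounds and at different places, which limits the comparison. Nothing shown here accounts for the size of the new step, and the series offers no independent measurement that bears on it.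

From the compounds shown here alone, whether a methyl group, a chloro group or an amine at this place would give a number nearer that of compound 3 or that of compound 4 remains open. Also open, going by these compounds, is whether the same replacement would have a step of similar size on the hydroxy-bearing core of compound 1 and compound 2.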